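The source may report more compounds than this note shows. Statements on the series, on what has been measured and on what is new or still open speak of the compounds shown alone.

Measured compounds:
- compound 1, `FC(F)(F)c1ccc(CN2CCN(Cc3cc(-c4ccc(OCc5ccccc5)cc4)on3)CC2)cc1`: 1700 nM
- compound 2, `Cc1ccccc1COc1ccc(-c2cc(CN3CCN(Cc4ccc(C(F)(F)F)cc4)CC3)no2)cc1`: 1200 nM
- compound 3, `FC(F)(F)c1ccc(CN2CCN(Cc3cc(-c4ccc(OCc5ccccc5Cl)cc4)on3)CC2)cc1`: 1000 nM

In a functional assay on Huh-7 cells (Homo sapiens) for antiproliferative activity, read by sulforhodamine B assay, with a stated time of 72 h (a higher number here means a weaker inhibitor, a lower number a stronger inhibitor), compound 2 gives 1200 nM, which places it between the other two numbers; its nearest neighbour is compound 3 and the furthest is compound 1, and both gaps are within the scatter. The three measured steps around the shared core, a 1.4-fold lower number from compound 1 to compound 2 (0.15 log units; within the scatter), a 1.7-fold lower number from compound 1 to compound 3 (0.23 log units; within the scatter) and a 1.2-fold lower number from compound 2 to compound 3 (0.08 log units; within the scatter), are all within the scatter, so no substituent change on the benzyloxy ring so far has moved this assay beyond noise.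

Compound 4, `Fc1ccc(COc2ccc(-c3cc(CN4CCN(Cc5ccc(C(F)(F)F)cc5)CC4)no3)cc2)cc1`, differs from compound 2 by 4-fluorophenyl in place of 2-methylphenyl on a saturated chain carbon bound to an oxygen on an aromatic ring. For the measured compounds named here, the steps that bear on this are the ones in which a hydrogen, a methyl or a chloro was exchanged on that same ring, and none of them was large. Going by the values given here, a fluorine on the ring is a new change, with no measured step of its own, so the expectation rests on the small steps seen so far. Compound 4 is therefore expected to give 1200 nM, with a range of 600 nM to 2400 nM, and the expected step of no change at the digits printed from compound 2 to compound 4 (within the scatter) lies within the scatter.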

Compound 4, half-maximal inhibitory concentration: 2000 nM
Beside the measured number, compound 4's estimate is 1.7-fold (0.22 log units) below it; low and high end bracket the measured number.
By their numbers in this assay, from the lowest: compounds 3, 2, 1 and 4 (each within the scatter of the next).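

In this assay, 4-fluorophenyl in place of 2-methylphenyl gives a 1.7-fold higher number from compound 2 to compound 4 (0.22 log units; within the scatter), and in place of 2-chlorophenyl it gives a 2.0-fold higher number from compound 3 to compound 4 (0.30 log units; within the scatter), while in place of the phenyl ring without a substituent it gives a 1.2-fold higher number from compound 1 to compound 4 (0.07 log units; within the scatter); all three steps are within the scatter. The earlier compounds tested only a hydrogen and groups named at the 2 position of the phenyl ring, so compound 4 extends the finding to a 4-substituted ring: at this saturated chain carbon bound to an oxygen on an aromatic ring, the four rings shown cannot be told apart in this assay, and no change among them has yet moved the number beyond noise. No measurement is at hand that could explain these small steps or say what, if anything, separates these rings.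

Going by these compounds, it remains open whether a group of a different kind on this ring, such as a carboxylic acid, an amine or a longer chain, would give a step beyond the scatter. The trifluoromethyl group is also the same in all four compounds, so these results say nothing about what replacing it, for instance with a nitrile, would do.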